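Sulfonyl-ring changes and HSP60/HSP10 inhibition: working notes

A few compounds are considered here, and "the series" means these few. Any claim that something is new, unique, unknown or untested is made for them only; others in the source may bear on it.

Compound 1 `O=S(=O)(Nc1ccc(-c2nc3ccccc3o2)cc1)c1cccs1` gives 63000 nM in an assay on cells for inhibition of HSP60/HSP10 (Homo sapiens), with a stated time of 60 min; a higher number here means a weaker inhibitor, a lower number a stronger inhibitor.
Compound 2 `O=S(=O)(Nc1ccc2oc(-c3ccccc3)nc2c1)c1ccccc1O` gives 85000 nM in this assay.
Compound 3 `COc1ccc(S(=O)(=O)Nc2ccc(-c3nc4ccccc4o3)cc2)cc1` reaches only the limit > 100000 nM in this assay, so no number is known for it.

Compound 2 holds the highest of the two numbers, with compound 1 nearest and within the scatter of it. The next compound, compound 4 `Cc1ccccc1S(=O)(=O)Nc1ccc2oc(-c3ccccc3)nc2c1`, differs from compound 2 by methyl in place of hydroxy on an aromatic carbon. Within the data shown here, the one measured step that also alters the ring on the sulfonyl sulfur is an at least 1.5-fold higher number from compound 1 to compound 3 (0.20 log units; that floor lies within the scatter), and it sits at the limit (the limit of > 100000 nM in this assay, at which 1 of the 3 values shown sits), so it gives little guidance. No step beyond the scatter is expected in this assay for compound 4, whose value is estimated at 90000 nM (range 40000 nM to 200000 nM), an expected step of a 1.1-fold higher number from compound 2 to compound 4 (0.02 log units; within the scatter).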

Compound 4, half-maximal inhibitory concentration: > 100000 nM
Compound 4: a limit, no number; the forecaster's own chance of this, stated with the estimate: 40%; middle value at least 1.1-fold (0.04 log units) from the limit.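

In this assay compound 4 stands at the limit > 100000 nM and has no number. On this aromatic carbon, ortho to a large group, methyl in place of hydroxy gives an at least 1.1-fold higher number from compound 2 to compound 4 (0.07 log units; that floor lies within the scatter) and so sets only a floor. The change from 2-hydroxyphenyl to 2-methylphenyl therefore shows no step beyond the scatter, and its true size stays unknown, with the series now crowding at the top of the range: the limit of > 100000 nM in this assay, at which 2 of the 4 values shown sit.

Open, as far as these compounds go, is whether an amine or a carboxylic acid at this same place would give a lower number than compound 2 does. From the compounds shown here alone, a longer chain there remains equally open.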